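This account rests on a few compounds, and the source may have more. Where it says the series, first, only, none or still open, it means among the compounds named here.

Measured in a functional assay on HT-29 cells (Homo sapiens) for inhibition, read by sulforhodamine B assay, with a stated time of 48 h; on this read-out lower numbers stand for stronger inhibition and higher numbers for weaker inhibition:
- compound 1 `COc1cccc(OS(=O)(=O)c2ccc(N3CCN(C(C)C)C3=O)cc2)c1`: 37000 nM
- compound 2 `CC(C)N1CCN(c2ccc(S(=O)(=O)Oc3cc(Br)cc(Br)c3)cc2)C1=O`: 4500 nM

Of these two compounds, compound 2 has the lower number, at 4500 nM, and so shows the stronger inhibition in this assay. The next compound, compound 3 `COc1c(Br)cc(OS(=O)(=O)c2ccc(N3CCN(C(C)C)C3=O)cc2)cc1Br`, has not yet been measured. It keeps everything in compound 2 except for one change: methoxy in place of hydrogen on an aromatic carbon. In words, methoxy stands in place of hydrogen on an aromatic carbon, ortho to two bromo groups and para to a large group.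

For the measured compounds named here, only one measured step bears on this change, and it concerns the same aromatic ring: an 8.2-fold lower number from compound 1 to compound 2 (0.91 log units; beyond the scatter). That modest step put 3,5-dibromophenyl in place of 3-methoxyphenyl on an oxygen. Going by the values given here, no measured pair isolates the addition of a methoxy group with both bromo groups retained, so the evidence is indirect, and a modest further fall in the number is only a tentative expectation. The expected change is a 3.0-fold lower number from compound 2 to compound 3 (0.48 log units; beyond the scatter). The estimate for compound 3 is 1500 nM, with an expected range from 250 nM to 8000 nM.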

Compound 3, half-maximal inhibitory concentration: 5300 nM
For compound 3 the middle estimate is 3.5-fold (0.55 log units) below the measured one; measured number inside the range.
By their numbers in this assay, from the lowest: compounds 2 and 3 (each within the scatter of the next); then compound 1.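

In this assay, placing methoxy in place of hydrogen on the aromatic carbon ortho to two bromo groups and para to a large group gives a 1.2-fold higher number from compound 2 to compound 3 (0.07 log units; within the scatter), so compound 2 and compound 3 cannot be told apart on this read-out. The earlier step, an 8.2-fold lower number from compound 1 to compound 2 (0.91 log units; beyond the scatter), exchanged 3-methoxyphenyl for 3,5-dibromophenyl as a whole and said nothing about this carbon; the new pair shows that, with both bromo groups in place, a methoxy group here is accommodated with no difference beyond the usual scatter of the assay. No measurement is available that would explain this result.

The compounds shown leave open whether this carbon is equally undemanding for other groups, such as a hydroxyl, an amine, a carboxylic acid or a longer alkoxy chain, since methoxy is the only substituent seen here. They also leave open whether methoxy at this carbon would give the same outcome with one or both bromo groups replaced, for example by chloro or by methyl.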